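The source may hold more compounds than are shown below. What is called first, only, known or untested is meant among the compounds shown, and "the series" means these compounds.

Measured so far in a functional assay on 3T3-L1 cells (Mus musculus) for inhibition, with a stated time of 20 min, tested at 20 uM; on this read-out higher numbers stand for more inhibition at the one concentration tested (going by the name of the read-out) and lower numbers for less inhibition:
- compound 1 `Cc1ccc(S(=O)(=O)n2cc(CN(Cc3cccc(F)c3F)C(=O)C(F)(F)F)c3ccccc32)cc1` gives -5.5%
- compound 2 `O=C(N(Cc1cccc(F)c1F)Cc1cn(S(=O)(=O)c2ccc(F)cc2)c2ccccc12)C(F)(F)F` gives -52.3%
- compound 3 `Cc1ccc(S(=O)(=O)n2cc(CN(Cc3cn(Cc4ccc(F)cc4)nn3)S(=O)(=O)c3ccccc3)c3ccccc32)cc1` gives -21%

Compound 1 stands highest of the three numbers in this assay; the nearest is compound 3, and the furthest is compound 2, both beyond the scatter. Among the compounds with values here, the one step between compounds differing in a single place is a number 46.8 percentage points lower from compound 1 to compound 2 (beyond the scatter), a large fall, though it concerns a substituent on an aromatic carbon and not the amine nitrogen.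

Compound 4 `Cc1ccc(S(=O)(=O)n2cc(CN(Cc3cccc(F)c3F)S(C)(=O)=O)c3ccccc32)cc1` is not yet measured. It differs from compound 1 at the amine nitrogen: methylsulfonyl in place of (trifluoromethyl)carbonyl on an amine nitrogen. Within the data shown here, no measured pair shows this change by itself. Among the measured compounds shown here, compound 3 carries a sulfonyl on its amine nitrogen but also differs elsewhere, so its value and that of compound 1 together say only that the sulfonyl-bearing compound sits lower, with no step assignable to the nitrogen substituent alone. The expectation in this assay is therefore for a modest step downward or none beyond the scatter, estimated as a number 9.5 percentage points lower from compound 1 to compound 4 (within the scatter). The expected value for compound 4 is -15%, within the range -45% to 10%.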

Compound 4, a percentage reported as inhibition, at one concentration (the size of the read-out at that concentration, not a potency): -3.3%
Estimate against measurement, compound 4: 11.7 percentage points below; the range from low to high includes it.
By their numbers in this assay, from the lowest: compound 2; then compound 3; then compounds 1 and 4 (each within the scatter of the next).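

In this assay, within the data shown here, the first reading of a change at the amine nitrogen alone is a number 2.2 percentage points higher from compound 1 to compound 4 (within the scatter) and so, on the core of compound 1, methylsulfonyl and (trifluoromethyl)carbonyl are not told apart by this read-out, even though the two groups share neither sulfur nor fluorine and differ in heavy atoms, double bonds and hydrogen-bond acceptors. Among these compounds, the position thus accepts this exchange between two groups without a ring or net charge, whereas the only other single-place step, a number 46.8 percentage points lower from compound 1 to compound 2 (beyond the scatter) and beyond the scatter, lies at an aromatic carbon and not at this nitrogen. No measurement available here bears on why the two groups read alike.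

Going by these compounds, whether the same exchange stays within the scatter when fluoro replaces methyl on the aromatic carbon, as in compound 2, remains open, and so does the single-place effect of the larger substituents on the amine nitrogen of compound 3. Also open is how the amine nitrogen behaves when it carries an acetyl, a benzoyl or a chain ending in a carboxylic acid, none of which appears among the compounds shown here.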